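This account rests on a few compounds, and the source may have more. Where it says the series, first, only, none or still open, it means among the compounds named here.

The measured compounds:

Compound 1, `COc1cc(Nc2ncnc3c(NC(=O)Nc4cc(F)cc(F)c4)cccc23)cc(OC)c1`: 2630 nM
Compound 2, `COc1cc(Nc2ncnc3c(NC(=O)Nc4cc(C)cc(C)c4)cccc23)cc(OC)c1`: 10100 nM
Compound 3, `COc1cc(Nc2ncnc3c(NC(=O)c4ccc(N5CCN(C)CC5)cc4)cccc23)cc(OC)c1`: 14200 nM

In a functional assay on RT-112 cells (Homo sapiens) for antiproliferative activity, read by MTT assay, with a stated time of 72 h (on this read-out higher numbers stand for weaker inhibition of growth and lower numbers for stronger inhibition of growth), compound 1 holds the lowest of the three numbers. The nearest neighbour is compound 2, which sits at a 3.8-fold higher number from compound 1 to compound 2 (0.58 log units; beyond the scatter), a step beyond the scatter. Compound 3 is the furthest of the set, and its value of 14200 nM lies beyond the scatter from compound 1 as well.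

Compound 4, `COc1cc(Nc2ncnc3c(NC(=O)c4ccc(CN(C)C)cc4)cccc23)cc(OC)c1`, has not yet been measured in this assay. It differs from compound 1 by 4-((dimethylamino)methyl)phenyl in place of (3,5-difluorophenyl)amino on a carbonyl carbon. For the measured compounds named here, only one measured step bears directly on this position, and only loosely: the exchange of 3,5-difluorophenyl for 3,5-dimethylphenyl on the amide-type nitrogen gave a 3.8-fold higher number from compound 1 to compound 2 (0.58 log units; beyond the scatter). Compound 3, which also carries an aryl group on the carbonyl carbon rather than an amino group, shows the weakest number of the three; compound 4 shares that arrangement. Compound 4 is therefore expected to give about 10000 nM, with a range from 3000 nM to 30000 nM. This estimate corresponds to an expected step of a 3.8-fold higher number from compound 1 to compound 4 (0.58 log units; beyond the scatter), towards weaker inhibition of growth.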

Compound 4, concentration for 50% growth inhibition: 4370 nM
Estimate against measurement, compound 4: 2.3-fold (0.36 log units) above; low and high end bracket the measured number.
By their numbers in this assay, from the lowest: compounds 1 and 4 (each within the scatter of the next); then compounds 2 and 3 (each within the scatter of the next).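

In this assay, the step from the amino-linked aryl group to an aryl group directly on the carbonyl carbon, with 4-((dimethylamino)methyl)phenyl entering, gives a 1.7-fold higher number from compound 1 to compound 4 (0.22 log units; within the scatter), so this change need not cost growth inhibition, as compound 3 alone had suggested it might. The group on the aromatic carbon of that aryl ring matters, since (dimethylamino)methyl in place of 4-methylpiperazin-1-yl gives a 3.2-fold lower number from compound 3 to compound 4 (0.51 log units; beyond the scatter). The same exchange on the carbonyl carbon is also no longer neutral when the leaving group is (3,5-dimethylphenyl)amino, which gives a 2.3-fold lower number from compound 2 to compound 4 (0.36 log units; beyond the scatter).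

Nothing available explains these differences. Going by these compounds, whether a pyrrolidine, a morpholine or a longer chain carrying the dimethylamino group would hold the number of compound 4 in this assay remains open.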